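A few compounds are considered here, and "the series" means these few. Any claim that something is new, unique, unknown or untested is made for them only; others in the source may bear on it.

Measured so far: compound 1 `O=C1NC(=O)/C(=C/c2ccc(OCN3C(=O)c4ccccc4C3=O)c([N+](=O)[O-])c2)S1`, compound 3 `O=C1NC(=O)/C(=C/c2cc([N+](=O)[O-])ccc2OCN2C(=O)c3ccccc3C2=O)S1`, and compound 2 `O=C1NC(=O)/C(=C/c2cc(Cl)ccc2OCN2C(=O)c3ccccc3C2=O)S1`. In an assay on isolated protein for inhibition of Alpha glucosidase (Homo sapiens), read by spectrophotometry, with stated times of 15 min and 30 min (a higher number here means a weaker inhibitor, a lower number a stronger inhibitor), compound 1 gives 22500 nM. Compound 3 gives 50500 nM. Compound 2 reaches only a limit of this assay, > 100000 nM, which is not a number (the limit of > 100000 nM in this assay, at which 1 of the 3 values shown sits).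

Among the measured compounds shown here, the one measured step, an at least 1.9-fold higher number from compound 3 to compound 2 (0.29 log units; that floor lies within the scatter), comes from the change (chloro in place of nitro on an aromatic carbon). Compound 4 `O=C1NC(=O)/C(=C/c2ccc(OCN3C(=O)c4ccccc4C3=O)c(Cl)c2)S1` is not yet measured; it arises from compound 1 by the same kind of change, (chloro in place of nitro on an aromatic carbon), though here the place is ortho to a large group and meta to a group of 8 heavy atoms rather than meta to a group of 8 heavy atoms and para to a large group. The difference between the cores of compound 1 and compound 3 is not broken down here.

Resting on the measured step from compound 3 to compound 2, compound 4 is expected to be weaker than compound 1 by about a 2.4-fold higher number from compound 1 to compound 4 (0.39 log units; beyond the scatter). Compound 4 is estimated at 55000 nM, between 20000 nM and 150000 nM.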

Compound 4, half-maximal inhibitory concentration: 21000 nM
Estimate against measurement, compound 4: 2.6-fold (0.42 log units) above; low and high end bracket the measured number.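

On one core, chloro in place of nitro gives a 1.1-fold lower number from compound 1 to compound 4 (0.03 log units; within the scatter), a step within the usual scatter, so on this core the swap shows no measurable effect. Set beside the earlier step, the same change on the two cores reads: the same change on two cores in this assay, an at least 1.9-fold higher number (0.29 log units; that floor lies within the scatter) from compound 3 to compound 2 and a 1.1-fold lower number (0.03 log units; within the scatter) from compound 1 to compound 4; the limit leaves it open whether they differ. As far as these compounds go, compound 2 gives only a limit of the assay, > 100000 nM, so the size of the earlier step stays unknown, and these data show neither that the change carries over from one core to the other nor that it depends on the core.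

The compounds shown leave open what an amine or a carboxylic acid in place of the nitro would give on either core.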